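A few compounds are considered here, and "the series" means these few. Any claim that something is new, unique, unknown or untested is made for them only; others in the source may bear on it.

Measured compounds in a functional assay on HBL-100 cells (Homo sapiens) for inhibition, read by sulforhodamine B assay, with a stated time of 48 h; a higher number here means a weaker inhibitor of growth, a lower number a stronger inhibitor of growth:
- compound 1, `CC(=O)OC/C(=C\C1CCCCC1)C(=O)c1ccccc1`, gives 21000 nM
- compound 2, `CC(=O)OC/C(=C\C1CCCCC1)C(=O)c1ccc(Cl)cc1`, gives 31000 nM
- compound 3, `CC(=O)OC/C(=C\c1ccc(Cl)cc1)C(=O)c1ccc(Cl)cc1`, gives 4000 nM

Compound 1 and compound 2 share a core and differ by chloro in place of hydrogen on an aromatic carbon; this gives a 1.5-fold higher number from compound 1 to compound 2 (0.17 log units; within the scatter). Compound 3 carries a 4-chlorophenyl in place of the cyclohexyl of compound 2, and that step is a 7.8-fold lower number from compound 2 to compound 3 (0.89 log units; beyond the scatter). Compound 3 has the lowest number of the three, and its steps to the other two lie beyond the scatter. How the core of compound 3 differs from the core of compound 1 is not broken down here.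

Compound 4, `CC(=O)OC/C(=C\c1ccc(Cl)cc1Cl)C(=O)c1ccc(Cl)cc1`, is not yet measured. It differs from compound 3 by chloro in place of hydrogen on an aromatic carbon. This is the same kind of change as that from compound 1 to compound 2, but at a different place: there the entering chloro sat para to a large group, here it sits ortho to a large group and meta to a chloro group.

Among the measured compounds shown here, the expectation for compound 4 rests on the only measured instance of this kind of change, which in the step of a 1.5-fold higher number from compound 1 to compound 2 (0.17 log units; within the scatter) stayed within the scatter. Compound 4 is therefore expected to stay close to compound 3, with an estimated step of a 1.1-fold higher number from compound 3 to compound 4 (0.05 log units; within the scatter). The estimate for compound 4 in this assay is 4500 nM, with a range from 2000 nM to 10000 nM.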

Compound 4, concentration for 50% growth inhibition: 3200 nM
Compound 4: the middle estimate sits 1.4-fold (0.15 log units) above what was measured, within the range that was stated.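

In this assay, chloro in place of hydrogen on an aromatic carbon gives a 1.3-fold lower number from compound 3 to compound 4 (0.10 log units; within the scatter), and this small step matches the earlier one on the other core: the same change on two cores in this assay, a 1.5-fold higher number (0.17 log units; within the scatter) from compound 1 to compound 2 and a 1.3-fold lower number (0.10 log units; within the scatter) from compound 3 to compound 4, 1.8-fold (0.27 log units) apart, within the scatter of two such steps Within these two pairs, the change therefore carries from one core to the other without a step beyond the scatter, while the larger step remains the replacement of cyclohexyl, seen in a 9.7-fold lower number from compound 2 to compound 4 (0.99 log units; beyond the scatter). Among the compounds shown here, this does not show that chloro is without consequence on other cores or at other places, since there are only two pairs in one assay and the entering chloro sits at a different place in each, ortho to a large group and meta to a chloro group in compound 4.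

Still open, on these data alone, is whether a methoxy group or an amine at the same place would also stay within the scatter, and whether an unsubstituted phenyl in place of cyclohexyl would give a step of similar size. All four compounds carry the acetate ester, so the compounds shown say nothing about a free hydroxyl or an amide at that position.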